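Homologating the acid on the pyrrolidine head group

The compounds below may be only part of what the source reports. "The series", "measured", "known", "first", "only" and "open" are said of these compounds alone.

Measured so far:
- compound 1 `CC(C)Cc1ccc(-c2nc(-c3ccc([C@H]4CC[C@@H](C(=O)O)N4)cc3)no2)cc1` — in an assay on CHO cells for displacement of a labelled ligand from sphingosine 1-phosphate receptor 4 (Homo sapiens) (on this read-out lower numbers stand for stronger inhibition and higher numbers for weaker inhibition), compound 1 gives 1000 nM
- compound 2 `CC(C)Cc1ccc(-c2nc(-c3ccc([C@@H]4CC[C@@H](C(=O)O)N4)cc3)no2)cc1` — in this assay compound 2 gives 300 nM

Compound 2 stands with the lowest number of the two measured compounds; compound 1, its nearest neighbour, sits at a higher number, and the step of a 3.3-fold lower number from compound 1 to compound 2 (0.52 log units; beyond the scatter) lies beyond the scatter. This step rests on the fact that compounds 1 and 2 differ only in the configuration as drawn alone, since the two share every atom and bond.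

Compound 3 `CC(C)Cc1ccc(-c2nc(-c3ccc([C@H]4CC[C@@H](CC(=O)O)N4)cc3)no2)cc1` differs from compound 2 by 5-(carboxymethyl)pyrrolidin-2-yl in place of 5-carboxypyrrolidin-2-yl on an aromatic carbon. For the measured compounds named here, no measured step touches this kind of change: the only step available, the stereochemical one from compound 1 to compound 2, concerns a configuration rather than a lengthening of the acid-bearing group, so it offers no guide to direction. The expectation for compound 3 is therefore a step of a 2.0-fold higher number from compound 2 to compound 3 (0.30 log units; within the scatter) with a wide range, on balance towards a somewhat higher number. Compound 3 is estimated at 600 nM, between 100 nM and 4000 nM.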

Compound 3, half-maximal inhibitory concentration: 1000 nM
The estimate for compound 3 lay 1.7-fold (0.22 log units) below the measured number; measured number inside the range.
By their numbers in this assay, from the lowest: compound 2; then compounds 1 and 3 (each within the scatter of the next).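

Replacing carboxy with carboxymethyl on the saturated ring carbon, with the drawn configuration kept, gives no change at the digits printed from compound 1 to compound 3 (within the scatter), so at this position the longer acid group can be tolerated in that configuration. The other comparison, a 3.3-fold higher number from compound 2 to compound 3 (0.52 log units; beyond the scatter), might at first look like a penalty for the longer group, but compound 3 is drawn with the configuration of compound 1, not that of compound 2. The higher number may therefore reflect configuration rather than chain length, because the earlier difference in the series rests on: the fact that compounds 1 and 2 differ only in the configuration as drawn

Still open, as far as these compounds go, is how carboxymethyl behaves in the configuration of compound 2, which would separate the two changes. Also open, from the compounds shown here alone, is whether a longer carboxyethyl chain, or a primary amide in place of the carboxylic acid, would hold the number at this position.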